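Past an Assay Limit: Estimating a New Side Chain

A few compounds are considered here, and "the series" means these few. Any claim that something is new, unique, unknown or untested is made for them only; others in the source may bear on it.

Of the compounds shown here, three sharing one core have been tested in a functional assay on HepG2 cells (Homo sapiens) for cytotoxicity, read by MTT assay, with a stated time of 48 h; a higher number here means a weaker inhibitor, a lower number a stronger inhibitor. Compound 1 `O=C(CSCc1nc2cc([N+](=O)[O-])ccc2[nH]1)c1ccccc1` gives 16100 nM in this assay, and compound 3 `CCOC(=O)c1c(NC(=O)CSCc2nc3cc([N+](=O)[O-])ccc3[nH]2)sc2c1CCCCC2` gives 7390 nM in this assay. Compound 2 `CCOC(=O)CSCc1nc2cc([N+](=O)[O-])ccc2[nH]1` stands apart: in this assay compound 2 reaches only a limit, > 100000 nM, so no number is known for it, only that it sits at the limit (the limit of > 100000 nM in this assay, at which 1 of the 3 values shown sits). For the measured compounds named here, the one step that connects two measured compounds at a single point of change runs an at least 6.2-fold higher number from compound 1 to compound 2 (0.79 log units; beyond the scatter), which means that swapping the phenyl for the ethoxy pushed the number out of the measurable range.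

Compound 4 `NC(=S)NNC(=O)CSCc1nc2cc([N+](=O)[O-])ccc2[nH]1` has not been measured. Its change from compound 2 is a group of 5 heavy atoms (1 carbon, 3 nitrogen, 1 sulfur; no ring) in place of a group of 3 heavy atoms (2 carbon, 1 oxygen; no ring), on a carbonyl carbon. Going by the values given here, the only measured step that bears on this is the one just described, and it shows that the ethoxy group at this carbonyl is linked with the weakest reading seen here, while a different group at the same place gave a measurable number. The entering group is not a phenyl, so the outcome is uncertain, but the expectation is a return toward measurable values, a step of an at least 2.5-fold lower number from compound 2 to compound 4 (0.39 log units; beyond the scatter). Compound 4 is therefore expected to give about 40000 nM in this assay, within a range from 10000 nM to 150000 nM.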

Compound 4, half-maximal inhibitory concentration: 7050 nM
Compound 4: middle estimate off by 5.7-fold (0.75 log units), on the high side; measured number below the stated range.
By their numbers in this assay, from the lowest: compounds 4 and 3 (each within the scatter of the next); then compound 1. At a limit, above all of these: compound 2.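

The new compound shows that a phenyl is not needed at this carbonyl carbon for a measurable reading in this assay: a group with no ring also brings the number back into range, with an at least 14-fold lower number from compound 2 to compound 4 (1.15 log units; beyond the scatter). The entering group does more than match the phenyl it is compared with, since the change gives a 2.3-fold lower number from compound 1 to compound 4 (0.36 log units; beyond the scatter), so a ring-free group with three hydrogen-bond donors can sit here and give the lower number of that pair. Compound 2 stands at a limit of the assay, so the larger of these two steps gives only a minimum size, not a measured one: the limit of > 100000 nM in this assay, at which 1 of the 4 values shown sits.

The compounds shown do not tell which part of the entering group goes with the lower number, the sulfur, the nitrogens or simply its greater size, and an oxygen in place of that sulfur, or a plain amine on the same carbonyl carbon, would begin to separate these. They also leave open whether a carboxylic acid or a longer carbon chain at this place would stay at the limit like the ethoxy or return to a measurable number.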